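Amino acid swap on the amide of compound 1

The source may hold more compounds than are shown below. What is called first, only, known or untested is meant among the compounds shown, and "the series" means these compounds.

Within the data shown here, of the two numbers so far in a functional assay on the whole organism (strain albino Sprague-Dawley) with Rattus norvegicus as the target, in the maximal electroshock model (on this read-out lower numbers stand for an effect already at smaller amounts and higher numbers for an effect only at larger amounts of compound), compound 1 `CC(C)(C)[C@@H](N)C(=O)NCc1ccc(COc2cccc(F)c2)cc1` gives 30 mg/kg. Compound 2 `CC(C)[C@@H](N)C(=O)NCc1ccc(OC(F)(F)F)cc1` gives 18 mg/kg in this assay, and the gap to compound 1 lies within the scatter, so no order between them is read. Compound 3 `CC(C)(C)[C@@H](N)C(=O)NCc1ccc(OCc2cccc(F)c2)cc1` returns only a limit in this assay, > 30 mg/kg, which is the limit of > 30 mg/kg in this assay, at which 1 of the 3 values shown sits. Compound 4 `CC(C)[C@H](N)C(=O)NCc1ccc(COc2cccc(F)c2)cc1` is not yet measured; it differs from compound 1 by 1-amino-2-methylpropyl in place of 1-amino-2,2-dimethylpropyl on a carbonyl carbon. Among the measured compounds shown here, no measured pair shows this change on its own. Compound 2 carries the same 1-amino-2-methylpropyl group and gives 18 mg/kg. For compound 4 a step of a 1.5-fold lower number from compound 1 to compound 4 (0.18 log units; within the scatter) is expected, not beyond the scatter. Compound 4 is estimated at 20 mg/kg, with a range from 8 mg/kg to 50 mg/kg.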

Compound 4, dose for half-maximal effect: > 30 mg/kg
Compound 4: a limit, no number; the forecaster's own chance of this, stated with the estimate: 25%; middle value at least 1.5-fold (0.17 log units) from the limit.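

At this position on the carbonyl carbon, 1-amino-2-methylpropyl in place of 1-amino-2,2-dimethylpropyl gives a number no lower from compound 1 to compound 4 (the limit leaves the size open) in this assay. The 1-amino-2-methylpropyl group therefore does not by itself secure a readable number on the core of compound 1. The result for compound 4 is a limit, not a number, and this outcome recurs in the series: the limit of > 30 mg/kg in this assay, at which 2 of the 4 values shown sit.

The defined stereocentre is also drawn opposite in compound 4, so the effects of chain and configuration cannot be separated. Open, as far as these compounds go, are the other configuration of 1-amino-2-methylpropyl on this core and a smaller 1-aminoethyl group.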